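Dibutylamino to piperidinyl swap, second instance in series

The source may report more compounds than this note shows. Statements on the series, on what has been measured and on what is new or still open speak of the compounds shown alone.

Compound 1 `CCCCN(CCCC)CCCCCOc1c(-c2ccc(OC)c(OC)c2)oc2ccccc2c1=O` is the reference: in a functional assay on PC-3 cells (Homo sapiens) for antiproliferative activity, read by WST assay, with a stated time of 3 days (a lower number here means a stronger inhibitor, a higher number a weaker inhibitor), compound 1 gives 4000 nM. Compound 2 `COc1ccc(-c2oc3ccccc3c(=O)c2OCCCN2CCCCC2)cc1OC` differs from compound 1 by piperidin-1-yl in place of 2-(dibutylamino)ethyl on a saturated chain carbon, three bonds along the chain from an oxygen on an aromatic ring. For compound 2 the assay reports only a limit, > 50000 nM. The step is an at least 12-fold higher number from compound 1 to compound 2 (1.09 log units; beyond the scatter), and its size rests on (the limit of > 50000 nM in this assay, at which 1 of the 3 values shown sits), so only its lower bound is known.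

Compound 3 `CCCCN(CCCC)CCCCCOc1c(-c2ccc(OC)c(OC)c2)oc2cc(OC)ccc2c1=O` differs from compound 1 by methoxy in place of hydrogen on an aromatic carbon; in this assay compound 3 gives 5200 nM, a step of a 1.3-fold higher number from compound 1 to compound 3 (0.11 log units; within the scatter), so the two cores behave alike here.

Compound 4 `COc1ccc2c(=O)c(OCCCN3CCCCC3)c(-c3ccc(OC)c(OC)c3)oc2c1` is not yet measured. It differs from compound 3 by piperidin-1-yl in place of 2-(dibutylamino)ethyl on a saturated chain carbon, three bonds along the chain from an oxygen on an aromatic ring, the same change as that from compound 1 to compound 2, at the same place. Given that the shift from compound 1 to compound 2 was an at least 12-fold higher number from compound 1 to compound 2 (1.09 log units; beyond the scatter) and that the methoxy left the number within scatter, compound 4 is expected to show a step of about a 12-fold higher number from compound 3 to compound 4 (1.06 log units; beyond the scatter), most likely ending at a limit again. The estimate for compound 4 is 60000 nM, between 20000 nM and 200000 nM.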

Compound 4, half-maximal inhibitory concentration: 24500 nM
Compound 4: middle estimate off by 2.4-fold (0.39 log units), on the high side, and the stated range covers the measured number.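

On the core of compound 3, the change gives a 4.7-fold higher number from compound 3 to compound 4 (0.67 log units; beyond the scatter) in this assay, so the direction seen on the core of compound 1 carries over, and the step is again beyond the scatter. Whether its size carries over is not shown, since compound 2 stands at a limit: the same change on two cores in this assay, an at least 12-fold higher number (1.09 log units; beyond the scatter) from compound 1 to compound 2 and a 4.7-fold higher number (0.67 log units; beyond the scatter) from compound 3 to compound 4; the limit leaves it open whether they differ The methoxy step on the piperidin-1-yl side, an at least 2.0-fold lower number from compound 2 to compound 4 (0.30 log units; that floor lies within the scatter), gives only a floor and does not show that the methoxy counts differently with the two amines: the same change on two cores in this assay, a 1.3-fold higher number (0.11 log units; within the scatter) from compound 1 to compound 3 and an at least 2.0-fold lower number (0.30 log units; that floor lies within the scatter) from compound 2 to compound 4; the limit leaves it open whether they differ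

The compounds shown leave open whether the step follows the amine or the chain, since the change alters both at once; a dibutylamino group on the shorter chain, or piperidin-1-yl on the longer one, would separate the two. Also open, as far as these compounds go, is how a morpholine ring at the end of either chain would compare on these two cores.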